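The source may hold more compounds than are shown below. What is called first, only, known or untested is meant among the compounds shown, and "the series" means these compounds.

In a functional assay on MCF7 cells (Homo sapiens) for inhibition, read by MTT assay, with a stated time of 72 h (a higher number here means a weaker inhibitor, a lower number a stronger inhibitor), compound 3 `Cc1cc(Nc2cc(-c3ccccc3)[nH]n2)n2nc(SCCCc3ccccc3)nc2n1` gives 3900 nM, and compound 1 `Cc1cc(Nc2cc(-c3ccccc3)[nH]n2)n2nc(SCc3ccc(F)cc3)nc2n1` gives 4020 nM. That is a 1.0-fold lower number from compound 1 to compound 3 (0.01 log units; within the scatter), so the two values cannot be told apart. Compound 2 `Cc1cc(Nc2cc(-c3ccccc3)[nH]n2)n2nc(SCC3CCCCC3)nc2n1` gives > 50000 nM, which is a limit of the assay. Compound 4 `Cc1ccc(CSc2nc3nc(C)cc(Nc4cc(-c5ccccc5)[nH]n4)n3n2)cc1` is still unmeasured, and its change from compound 3 is 4-methylphenyl in place of phenethyl on a saturated chain carbon bound to a sulfur. The large steps, an at least 12-fold higher number from compound 1 to compound 2 (1.09 log units; beyond the scatter) and an at least 12-fold lower number from compound 2 to compound 3 (1.10 log units; beyond the scatter), both involve the cyclohexyl of compound 2, which compound 4 lacks. Compound 4 keeps an aromatic ring, as compound 1 does with 4020 nM, so no step beyond the scatter is expected in this assay. The expected step is a 1.0-fold higher number from compound 3 to compound 4 (0.01 log units; within the scatter). Compound 4 is estimated at 4000 nM, within a range of 1500 nM to 11000 nM.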

Compound 4, half-maximal inhibitory concentration: 7290 nM
Beside the measured number, compound 4's estimate is 1.8-fold (0.26 log units) below it; low and high end bracket the measured number.
By their numbers in this assay, from the lowest: compounds 3, 1 and 4 (each within the scatter of the next). At a limit, above all of these: compound 2.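

A methyl in place of the fluoro on the aromatic carbon gives no step beyond the scatter, a 1.8-fold higher number from compound 1 to compound 4 (0.26 log units; within the scatter), and neither does exchanging the phenethyl for the 4-methylphenyl, a 1.9-fold higher number from compound 3 to compound 4 (0.27 log units; within the scatter), so three aromatic groups on the saturated chain carbon bound to a sulfur cannot be told apart. The cyclohexyl alone stands off from them, an at least 6.8-fold lower number from compound 2 to compound 4 (0.83 log units; beyond the scatter). The value of compound 2 is a limit, not a number: the limit of > 50000 nM in this assay, at which 1 of the 4 values shown sits.

Still open, from the compounds shown here alone, is whether an amine or a carboxylic acid in place of the methyl on the aromatic carbon would keep the number within the scatter.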